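This account rests on a few compounds, and the source may have more. Where it says the series, first, only, none or still open, it means among the compounds named here.

In a functional assay on A2780 cells (Homo sapiens) for antiproliferative activity, read by MTT assay, with a stated time of 72 h (a lower number here means a stronger inhibitor, a higher number a weaker inhibitor), compound 1, `O=C(c1cc2ccccc2o1)N1N=C(c2ccc(F)cc2)CC1c1ccccc1`, gives 11.8 ug/mL. Compound 2, `O=C(c1cc2ccccc2o1)N1N=C(c2ccc(F)cc2)CC1c1ccc(Cl)cc1`, gives > 50 ug/mL, which is a limit of the assay and not a number. For the measured compounds named here, compound 3, `O=C(c1cc2ccccc2o1)N1N=C(c2ccc(F)cc2)CC1c1ccccc1Cl`, gives 45.2 ug/mL, the higher of the two true numbers, and compound 1 is its only neighbour with a true number.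

Compound 4, `COc1ccc(C2CC(c3ccc(F)cc3)=NN2C(=O)c2cc3ccccc3o2)cc1OC`, keeps the shared core and changes one group: 3,4-dimethoxyphenyl in place of 2-chlorophenyl on a saturated ring carbon. In words, 3,4-dimethoxyphenyl stands in place of 2-chlorophenyl on a saturated ring carbon.

Going by the values given here, three measured steps concern this same group. Chloro in place of hydrogen on an aromatic carbon gave an at least 4.2-fold higher number from compound 1 to compound 2 (0.62 log units; beyond the scatter), and the same kind of change gave a 3.8-fold higher number from compound 1 to compound 3 (0.58 log units; beyond the scatter). Both moved the number upward, so both chlorinated compounds are poorer inhibitors than compound 1. Exchanging 4-chlorophenyl for 2-chlorophenyl gave an at least 1.1-fold lower number from compound 2 to compound 3 (0.04 log units; that floor lies within the scatter), and that floor lies within the scatter. Among the compounds with values here, no measured compound carries a methoxy group, so this evidence is indirect.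

Compound 4 also carries a substituted ring, so its number is expected to stay near compound 3 at 45.2 ug/mL, with some room toward compound 1 at 11.8 ug/mL. The expected change is a 1.5-fold lower number from compound 3 to compound 4 (0.18 log units; within the scatter), which would be no clear step beyond the scatter. For compound 4 the estimated value is 30 ug/mL, with an expected range from 10 ug/mL to 60 ug/mL.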

Compound 4, half-maximal inhibitory concentration: > 50 ug/mL
Compound 4: only a limit was reported (the forecaster's own chance of this, stated with the estimate: 30%); at least 1.6-fold (0.22 log units) between middle value and limit.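

Compound 4 and compound 2 each give a limit of the assay, not a number: the limit of > 50 ug/mL in this assay, at which 2 of the 4 values shown sit. The new information lies in the change of group: in this assay, a phenyl group carrying two methoxy groups also does worse than the plain phenyl, with an at least 4.2-fold higher number from compound 1 to compound 4 (0.62 log units; beyond the scatter), so the loss at this saturated ring carbon is no longer tied to chloro alone, and all three substituted phenyl groups shown have weaker results than the unsubstituted phenyl of compound 1, with no compound shown going against this. Compared with the 2-chlorophenyl group, the result is an at least 1.1-fold higher number from compound 3 to compound 4 (0.04 log units; that floor lies within the scatter), so no order can be set between compound 3 and compound 4, and the step between compound 2 and compound 4 cannot be read.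

As far as these compounds go, how far compound 2 and compound 4 lie past the limit stays open, so the substituted groups that reach it cannot be ranked against each other. Also open, from the compounds shown here alone, is whether any group on this phenyl ring can improve on compound 1, such as a single hydroxyl, an amine or a carboxylic acid.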